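Alkyne substituent removal in the series: compound 3 to compound 4

The compounds below may be only part of what the source reports. "The series", "measured", "known", "first", "only" and "open" are said of these compounds alone.

Measured in a functional assay on MCF7 cells (Homo sapiens) for antiproliferative activity, read by MTT assay, with a stated time of 24 h; on this read-out lower numbers stand for stronger inhibition and higher numbers for weaker inhibition:
- Compound 1 `CCN(CC)CCNC(=O)C1CC(C(CC)(CC)c2ccc(C#CC(C)(O)CC)c(C)c2)=CN1CC` gives 2780 nM
- Compound 2 `CCCC(O)(C#Cc1ccc(C(CC)(CC)C2=CN(CC)C(C(=O)NCCN(CC)CC)C2)cc1C)CCC` gives 1290 nM
- Compound 3 `CCN(CC)CCNC(=O)C1CC(C(CC)(CC)c2ccc(C#CC(O)C3CCCCC3)c(C)c2)=CN1CC` gives 3070 nM

Compound 3 stands at the upper end of the three numbers, and the two steps that reach it differ: a 1.1-fold higher number from compound 1 to compound 3 (0.04 log units; within the scatter), and a 2.4-fold higher number from compound 2 to compound 3 (0.38 log units; beyond the scatter). The next structure, compound 4 `C#Cc1ccc(C(CC)(CC)C2=CN(CC)C(C(=O)NCCN(CC)CC)C2)cc1C`, has hydrogen in place of cyclohexyl(hydroxy)methyl on a triple-bonded carbon.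

The measured steps all exchange one group on the triple-bonded carbon for another. They remain small: a 2.2-fold lower number from compound 1 to compound 2 (0.33 log units; beyond the scatter), and the widest is a 2.4-fold higher number from compound 2 to compound 3 (0.38 log units; beyond the scatter). Among the measured compounds shown here, none of them removes the group altogether, and no measured compound carries hydrogen at this place, so the step to compound 4 is an extrapolation and its direction is poorly supported. On these small steps, a large change in this assay is not expected, with only a slight lean towards a higher number and nothing firmly beyond the scatter. The expected step is a 1.3-fold higher number from compound 3 to compound 4 (0.11 log units; within the scatter). For compound 4 the estimated value is 4000 nM, with an expected range from 1500 nM to 12000 nM.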

Compound 4, half-maximal inhibitory concentration: > 50000 nM
Compound 4 gave a limit, no number; the forecaster's own chance of this, stated with the estimate: 10%; middle value at least 12-fold (1.09 log units) away from the limit.
By their numbers in this assay, from the lowest: compound 2; then compounds 1 and 3 (each within the scatter of the next). At a limit, above all of these: compound 4.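

In this assay, compound 4 gives a limit and not a number: the limit of > 50000 nM in this assay, at which 1 of the 4 values shown sits.

The earlier exchanges on the triple-bonded carbon replaced one oxygen-bearing group with another and stayed modest or within the scatter, whereas hydrogen at this place gives an at least 16-fold higher number from compound 3 to compound 4 (1.21 log units; beyond the scatter), alongside an at least 17-fold higher number from compound 1 to compound 4 (1.25 log units; beyond the scatter) and an at least 38-fold higher number from compound 2 to compound 4 (1.58 log units; beyond the scatter). The position therefore accepts all three oxygen-bearing groups shown, but losing the group altogether carries a large penalty, and no compound shown goes against this. As all three new steps rest on a limit, they give only a minimum size for the penalty.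

Each substituted compound shown carries both a hydroxyl and a carbon framework on this position, so their separate contributions remain open, and a tert-butyl group or an amine-bearing group such as dimethylaminomethyl on the triple-bonded carbon would begin to separate them. From the compounds shown here alone, how much of the group is needed also remains open, and a small group such as methyl or hydroxymethyl would test the range between hydrogen and the larger groups.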